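A few compounds are considered here, and "the series" means these few. Any claim that something is new, unique, unknown or untested is made for them only; others in the source may bear on it.

In a functional assay on HT-29 cells (Homo sapiens) for cytotoxicity, read by sulforhodamine B assay (a lower number here means a stronger inhibitor, a higher number a weaker inhibitor), compound 1 (`C=C1[C@@H](OC(C)=O)C[C@@H]2[C@](C)(CO[Si](C)(C)C(C)(C)C)[C@H](OC(C)=O)CC[C@@]2(C)[C@@H]1C[C@@H](Nc1ccc(O)cc1)C1=CCOC1=O`) gives 6140 nM and compound 2 (`C=C1[C@@H](OC(C)=O)C[C@@H]2[C@](C)(COC=O)[C@H](OC(C)=O)CC[C@@]2(C)[C@@H]1C[C@@H](Nc1cccc2ccccc12)C1=CCOC1=O`) gives 8670 nM. Compound 3 (`C=C1[C@@H](OC(C)=O)C[C@@H]2[C@](C)(CO[Si](C)(C)C(C)(C)C)[C@H](OC(C)=O)CC[C@@]2(C)[C@@H]1C[C@@H](Nc1cccc(OC)c1)C1=CCOC1=O`) reads > 50000 nM, which is a limit of the assay and not a number. Compound 4 (`C=C1[C@@H](OC(C)=O)C[C@@H]2[C@](C)(CO[Si](C)(C)C(C)(C)C)[C@H](OC(C)=O)CC[C@@]2(C)[C@@H]1C[C@@H](Nc1cccc2ccccc12)C1=CCOC1=O`) departs from compound 3 by naphthalen-1-yl in place of 3-methoxyphenyl on an amine nitrogen. Within the data shown here, the only measured step at that nitrogen is an at least 8.1-fold higher number from compound 1 to compound 3 (0.91 log units; beyond the scatter), so the group there can matter in this assay. Differing from compound 4 elsewhere, compound 2 carries the same naphthalen-1-yl group and gives 8670 nM. A lower number is therefore expected, an estimated at least 4.5-fold lower number from compound 3 to compound 4 (0.65 log units; beyond the scatter). For compound 4 the expected value is 11000 nM, with a range of 3500 nM to 40000 nM.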

Compound 4, half-maximal inhibitory concentration: 15000 nM
Beside the measured number, compound 4's estimate is 1.4-fold (0.13 log units) below it; the range from low to high includes it.
By their numbers in this assay, from the lowest: compounds 1, 2 and 4 (each within the scatter of the next, the first and the last beyond it). At a limit, above all of these: compound 3.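

In this assay, naphthalen-1-yl in place of 3-methoxyphenyl on the amine nitrogen gives an at least 3.3-fold lower number from compound 3 to compound 4 (0.52 log units; beyond the scatter), while naphthalen-1-yl in place of 4-hydroxyphenyl gives a 2.4-fold higher number from compound 1 to compound 4 (0.39 log units; beyond the scatter), so the number at this nitrogen moves both ways with the group. With naphthalen-1-yl held fixed, the change on the oxygen on a saturated carbon gives a 1.7-fold higher number from compound 2 to compound 4 (0.24 log units; within the scatter), which stays within the scatter. The reading for compound 3 is a limit of the assay and not a number: the limit of > 50000 nM in this assay, at which 1 of the 4 values shown sits.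

On these data alone, how a benzyl or cyclohexyl group on that nitrogen would read remains open, as does a free hydroxyl on that oxygen.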